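Halogenated thiophene ketones on the shared core

The compounds below may be only part of what the source reports. "The series", "measured", "known", "first", "only" and "open" are said of these compounds alone.

Going by the values given here, compound 2 `CC(C)Nc1sc(C(=O)c2ccc(I)s2)c(N)c1C#N` gives 112 nM in an assay for inhibition of Maternal embryonic leucine zipper kinase (Homo sapiens), read by ADP-Glo, with a stated time of 0.5 h (a lower number here means a stronger inhibitor, a higher number a weaker inhibitor), the only numerical value so far. Compound 1 `CC(C)Nc1sc(C(=O)c2ccncc2)c(N)c1C#N` reaches the limit of > 5000 nM in this assay, so its value is a limit and not a number (the limit of > 5000 nM in this assay, at which 1 of the 2 values shown sits). The step of an at least 44-fold lower number from compound 1 to compound 2 (1.64 log units; beyond the scatter) is large, so the group on the carbonyl carbon matters. Compound 3 `CC(C)Nc1sc(C(=O)c2cc(Br)cs2)c(N)c1C#N` differs from compound 2 by 4-bromothiophen-2-yl in place of 5-iodothiophen-2-yl on a carbonyl carbon. Among the compounds with values here, no measured step moves a halogen within the ring on the carbonyl carbon, so no direct precedent exists. The step is expected to be a 2.2-fold higher number from compound 2 to compound 3 (0.35 log units; beyond the scatter), a modest weakening. Compound 3 is estimated at 250 nM, with a range from 80 nM to 800 nM.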

Compound 3, half-maximal inhibitory concentration: 599 nM
Compound 3: middle estimate off by 2.4-fold (0.38 log units), on the low side; the range from low to high includes it.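

Pyridin-4-yl to 4-bromothiophen-2-yl on the carbonyl carbon also lowers the number (an at least 8.3-fold lower number from compound 1 to compound 3 (0.92 log units; beyond the scatter)), so this gain is not confined to 5-iodothiophen-2-yl. The two halogenated thiophenes still differ (a 5.3-fold higher number from compound 2 to compound 3 (0.73 log units; beyond the scatter)), so the identity of the thiophene substituent, and not the thiophene alone, affects inhibition. The comparison with compound 1 rests on a limit and not a number: the limit of > 5000 nM in this assay, at which 1 of the 3 values shown sits.

Halogen and ring place change together between compound 2 and compound 3, so their contributions remain inseparable. Also open, from the compounds shown here alone, is whether an unsubstituted thiophene, or a thiophene carrying chlorine, an amine or a carboxylic acid, retains inhibition.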